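Methoxy for Methyl on a Fused Bicyclic Core

The compounds below may be only part of what the source reports. "The series", "measured", "known", "first", "only" and "open" are said of these compounds alone.

The set gathered here rests on one shared core, carried by compound 1 `CC[C@H](C)n1c(=O)[nH]c2ncc(Br)nc21`, compound 2 `O=c1[nH]c2ncc(Br)nc2n1C1CC1`, compound 3 `CCC(CC)n1c(=O)[nH]c2ncc(C)nc21` and the still unmeasured compound 4 `CCC(CC)n1c(=O)[nH]c2ncc(OC)nc21`. In an ADME assay on microsomes from liver (Rattus norvegicus), read by LC-MS, with a stated time of 90 min (a higher number here means that the liver removes a larger share of the compound in one pass, a lower number that the liver removes a smaller share), compound 1 gives 0.3. For compound 2 the entry in this assay reads "not determined" (no result reported), so no number is available for it. Compound 3 gives 0.7 in this assay, the highest of the two numbers available; the nearest number is that of compound 1, which lies lower by an amount beyond the usual scatter. For the measured compounds named here, no pair of measured compounds differs in only one place, so no single step can be read from the numbers themselves.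

Compound 4 differs from compound 3 in one place: methoxy in place of methyl on an aromatic carbon. The change sits on an aromatic carbon of a six-membered aromatic ring with two nitrogens, part of the fused system of two rings.

Going by the values given here, with no measured step of this kind available, the author expects only a small step from compound 3 to compound 4 in this assay, a number 0.050 higher from compound 3 to compound 4 (within the scatter), leaning slightly upward and close to the scatter. Compound 4 is therefore estimated at 0.75 in this assay, with a range from 0.55 to 0.9.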

Compound 4, hepatic extraction ratio: > 0.7
Compound 4 ended at the assay's limit (the forecaster's own chance of this, stated with the estimate: 5%); the middle value does not contradict the limit.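

In this assay compound 4 gives > 0.7, which is a limit of the assay and not a number. For the compounds shown here, this is the only step in the set that changes a single place, and putting methoxy in place of methyl on this aromatic carbon, next to the ring nitrogen, gives a number no lower from compound 3 to compound 4 (the limit leaves the size open). The set thus shows for the first time that this change at this position does not bring the share removed by the liver down, while the size of the step cannot be read, and compound 4 stands at the edge of what the read-out reports: the limit of > 0.7 in this assay, at which 1 of the 4 values shown sits.

The compounds shown leave open whether the same change would give a similar result with the side chains carried by compound 1 and compound 2, where the group on this carbon is bromo rather than methyl. They also leave open what an amine, a hydroxyl group or a longer chain such as ethoxy on this aromatic carbon would give in this assay, and whether any of these would bring the read-out back into the range where it yields a number.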